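Replacing trifluoromethyl with hydrogen on a hydrazide series

The source may report more compounds than this note shows. Statements on the series, on what has been measured and on what is new or still open speak of the compounds shown alone.

Measured compounds:
- compound 2, `O=C(NNc1nncc2ccccc12)C1CC1c1ccc(OCC(F)(F)F)cc1`: 8000 nM
- compound 3, `O=C(NNC(=O)C1CC1c1ccc(OCC(F)(F)F)cc1)c1ccncc1`: 34000 nM
- compound 1, `CC(C)=CCC/C(C)=C/COc1ccc(C2CC2C(=O)NNC(=O)c2ccncc2)cc1`: "not determined" (no result reported)

The measurements come from a functional assay on MCF7 cells (Homo sapiens) for inhibition, read by MTT assay, with a stated time of 72 h; a lower number here means a stronger inhibitor, a higher number a weaker inhibitor. Compound 2 gives the lowest of the two reported numbers; compound 3 sits at a higher number, and the gap between compound 2 and compound 3 is beyond the usual scatter. Compound 1 carries no reported result.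

The next compound, compound 4, has the structure `COc1ccc(C2CC2C(=O)NNc2nncc3ccccc23)cc1`. It differs from compound 2 in a single place: hydrogen in place of trifluoromethyl on a saturated chain carbon bound to an oxygen on an aromatic ring. Going by the values given here, nothing in the reported pairs shows a change of this kind, so no measured step can guide the size of the effect. With the rest of compound 2 kept, the expectation is a step from compound 2 to compound 4 of a 1.5-fold higher number from compound 2 to compound 4 (0.18 log units; within the scatter) in this assay, most likely a modest move toward a weaker number, but possibly none beyond the scatter.

Compound 4 is therefore estimated at 12000 nM in this assay, with a plausible range from 4000 nM to 40000 nM.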

Compound 4, half-maximal inhibitory concentration: 72000 nM
Compound 4: middle estimate off by 6.0-fold (0.78 log units), on the low side; the measured number lies above the stated range.
By their numbers in this assay, from the lowest: compound 2; then compound 3; then compound 4.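

In this assay, replacing trifluoromethyl with hydrogen, which turns 2,2,2-trifluoroethoxy into methoxy, gives a 9.0-fold higher number from compound 2 to compound 4 (0.95 log units; beyond the scatter), a step beyond the usual scatter. Going by these compounds alone, this is the only measured step between compounds that differ in one place, and it shows that a change on this saturated chain carbon bound to an oxygen on an aromatic ring can clearly shift the number, with the trifluoromethyl compound having the lower one. Nothing at hand explains this shift.

As far as these compounds go, it remains open whether all of the trifluoromethyl is needed, since a difluoromethyl or a plain methyl at the same place would give intermediate cases. From the compounds shown here alone, it also remains open whether the same change would give a similar step on the other end of the molecule found in compound 3.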